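Replacing a methylsulfanyl-phenyl urea with a bromophenyl urea

The compounds below may be only part of what the source reports. "The series", "measured", "known", "first", "only" and "open" are said of these compounds alone.

Measured so far:
compound 1 `O=C(Nc1cccc(C(F)(F)F)c1)N[C@H]1CC[C@H](Oc2cccc(C(F)(F)F)c2)CC1`: 1300 nM
compound 2 `O=C(Nc1cccc(C(F)(F)F)c1)N[C@H]1CC[C@@H](Oc2ccc(F)cc2)CC1`: 2600 nM
compound 3 `CSc1ccccc1NC(=O)N[C@H]1CC[C@H](Oc2ccc(F)cc2)CC1`: > 20000 nM

In a functional assay on CRL2813 cells (Homo sapiens) for cytotoxicity, read by sulforhodamine B assay, with a stated time of 5 days (on this read-out lower numbers stand for stronger inhibition and higher numbers for weaker inhibition), compound 3 reaches only a limit, > 20000 nM, so no number is known for it. This is the limit of > 20000 nM in this assay, at which 1 of the 3 values shown sits, and marks the weak end of the three values shown. Compound 4 `O=C(Nc1cccc(Br)c1)N[C@H]1CC[C@H](Oc2ccc(F)cc2)CC1` differs from compound 3 in one place: 3-bromophenyl in place of 2-(methylsulfanyl)phenyl on an amide-type nitrogen. Among the compounds with values here, no measured pair shows this change directly, so its size cannot be read off. Compound 1 gives 1300 nM and compound 2 gives 2600 nM, both well within the measurable range. Compound 4 is therefore expected to move back into that range, with the estimated step of an at least 5.7-fold lower number from compound 3 to compound 4 (0.75 log units; beyond the scatter) towards stronger inhibition. The expected value for compound 4 is 3500 nM, within 1000 nM to 12000 nM.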

Compound 4, half-maximal inhibitory concentration: 6200 nM
Estimate against measurement, compound 4: 1.8-fold (0.25 log units) below; the measured number falls inside the stated range.
By their numbers in this assay, from the lowest: compounds 1 and 2 (each within the scatter of the next); then compound 4. At a limit, above all of these: compound 3.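

In this assay, 3-bromophenyl in place of 2-(methylsulfanyl)phenyl on the amide-type nitrogen gives an at least 3.2-fold lower number from compound 3 to compound 4 (0.50 log units; beyond the scatter), with the rest of the molecule unchanged. Within the data shown here, this single change therefore brings a compound from a limit to a measurable value, which the earlier compounds could not show. Compound 3 stands at a limit and not at a number, so the step has only a lower bound: the limit of > 20000 nM in this assay, at which 1 of the 4 values shown sits.

The group and its place on the phenyl ring change together, and the compounds shown do not separate the two. On these data alone, how an amine or a carboxylic acid on that ring would read also remains open.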